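This account rests on a few compounds, and the source may have more. Where it says the series, first, only, none or still open, it means among the compounds named here.

Working notes on the series in a functional assay on MRC5 cells (Homo sapiens) for cytotoxicity, read by MTT assay, with a stated time of 48 h; a lower number here means a stronger inhibitor, a higher number a weaker inhibitor. Compound 1 `O=C(O[C@H]1C[C@H](n2cc(F)c(=O)[nH]c2=O)O[C@@H]1COP(=O)(O)Oc1cccnc1)c1ccccc1` gives 15600 nM. Compound 2 `C[n+]1cccc(OP(=O)([O-])OC[C@H]2O[C@@H](n3cc(F)c(=O)[nH]c3=O)C[C@@H]2OC(=O)c2ccccc2)c1` gives 5750 nM, the lowest of the three numbers, with a 2.7-fold lower number from compound 1 to compound 2 (0.43 log units; beyond the scatter). Compound 3 `CCCCCCCCCC[n+]1cccc(OP(=O)([O-])OC[C@H]2O[C@@H](n3cc(F)c(=O)[nH]c3=O)C[C@@H]2OC(=O)c2ccccc2)c1` gives 14100 nM, with a 2.5-fold higher number from compound 2 to compound 3 (0.39 log units; beyond the scatter). Compound 4 `C[N+]1(C)CCC(OP(=O)([O-])OC[C@H]2O[C@@H](n3cc(F)c(=O)[nH]c3=O)C[C@@H]2OC(=O)c2ccccc2)CC1` is not yet measured; it differs from compound 2 as follows: a group of 8 heavy atoms (7 carbon, 1 nitrogen; one six-membered non-aromatic ring with 1 hetero atom) in place of a group of 7 heavy atoms (6 carbon, 1 nitrogen; one six-membered aromatic ring with 1 hetero atom), on an oxygen. Neither measured step exchanges the ring on that oxygen, so the two steps bear only loosely on it; both are modest and point in opposite directions. No step beyond the scatter is therefore expected; the step from compound 2 to compound 4 is estimated at a 1.4-fold higher number from compound 2 to compound 4 (0.14 log units; within the scatter). Compound 4 is expected to give about 8000 nM, within a range from 3000 nM to 25000 nM.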

Compound 4, half-maximal inhibitory concentration: 8300 nM
For compound 4 the middle estimate is 1.0-fold (0.02 log units) below the measured one; the measured number falls inside the stated range.
By their numbers in this assay, from the lowest: compounds 2, 4, 3 and 1 (each within the scatter of the next, the first and the last beyond it).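

In this assay, among the compounds shown here, the first exchange of the ring on this oxygen, whose other neighbour is phosphorus, swaps the aromatic ring for the non-aromatic one at the same net charge of +1, and the result stays within the scatter: a 1.4-fold higher number from compound 2 to compound 4 (0.16 log units; within the scatter). The step of a 1.9-fold lower number from compound 1 to compound 4 (0.27 log units; within the scatter) also lies within the scatter, whereas a 2.7-fold lower number from compound 1 to compound 2 (0.43 log units; beyond the scatter) lies beyond it. No measurement shown accounts for these steps. Still open, from the compounds shown here alone, is whether an open-chain trimethylammonium group in place of the ring would hold the number. Also open, going by these compounds, is whether nonyl on compound 4 would repeat a 2.5-fold higher number from compound 2 to compound 3 (0.39 log units; beyond the scatter).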